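Swapping a Nitrile for an Acetamido Group

The compounds below may be only part of what the source reports. "The series", "measured", "known", "first", "only" and "open" are said of these compounds alone.

Measured so far:
Compound 1, `C=CC[C@H]1C[C@]2([C@@H](C)Cc3ccc(OC)c(C(N)=O)c3)OCOC2=CC1=O`, 66 nM
Compound 2, `C=CC[C@H]1C[C@]2([C@@H](C)Cc3ccc(OC)c(C#N)c3)OCOC2=CC1=O`, 340 nM

These two compounds share one core and differ only in the group on the aromatic ring. In a functional assay on NCI-H460 cells (Homo sapiens) for antiproliferative activity, with a stated time of 72 h (a lower number here means a stronger inhibitor, a higher number a weaker inhibitor), compound 2 has the higher of the two numbers; its nearest neighbour is compound 1, and the step of a 5.2-fold higher number from compound 1 to compound 2 (0.71 log units; beyond the scatter) shows how much weaker the nitrile-bearing compound is than the one with the primary amide.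

Compound 3, `C=CC[C@H]1C[C@]2([C@@H](C)Cc3ccc(OC)c(NC(C)=O)c3)OCOC2=CC1=O`, is not yet measured. It differs from compound 2 by acetamido in place of cyano on an aromatic carbon. For the measured compounds named here, the only step that bears on this change is a 5.2-fold higher number from compound 1 to compound 2 (0.71 log units; beyond the scatter), where a group with a hydrogen-bond donor and acceptor was replaced by a nitrile with none. The acetamido group brings a donor and an acceptor back, so part of that loss is expected to be recovered, though the new group is larger than the carbamoyl of compound 1. Compound 3 is therefore expected to give 130 nM in this assay, in the range 45 nM to 400 nM, a step of a 2.6-fold lower number from compound 2 to compound 3 (0.42 log units; beyond the scatter).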

Compound 3, half-maximal inhibitory concentration: 310 nM
For compound 3 the middle estimate is 2.4-fold (0.38 log units) below the measured one, within the range that was stated.
By their numbers in this assay, from the lowest: compound 1; then compounds 3 and 2 (each within the scatter of the next).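

Placing acetamido instead of cyano on this aromatic carbon gives a 1.1-fold lower number from compound 2 to compound 3 (0.04 log units; within the scatter) in this assay and so, although compound 3 carries a hydrogen-bond donor and compound 2 has none, adding that donor does not separate the two compounds. Acetamido in place of carbamoyl gives a 4.7-fold higher number from compound 1 to compound 3 (0.67 log units; beyond the scatter) and shows that having a donor on this carbon is not enough to match compound 1, whose carbamoyl stands apart from both the cyano and the acetamido group. No measurement here explains why the carbamoyl group stands apart.

On these data alone, it remains open whether a carboxylic acid or a methyl ester on this carbon would match compound 1 or sit with compound 2 and compound 3. The plain amine, which lacks the acetyl part of compound 3, is equally untested among the compounds shown.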